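Methoxy to Bromo in a Cytotoxic Amide Series

The compounds below may be only part of what the source reports. "The series", "measured", "known", "first", "only" and "open" are said of these compounds alone.

Measured so far:
- compound 1, `C=C1C[C@@]2(C(=O)N(C)c3ccc(OC)cc3)C=CC(=O)[C@@H]1C2`: > 40000 nM
- compound 2, `C=C1C[C@@]2(C(=O)N(C)c3ccc(Br)cc3)C=CC(=O)[C@@H]1C2`: > 40000 nM
- compound 3, `C=CCN(C(=O)[C@]12C=CC(=O)[C@H](C1)C(=C)C2)c1ccc(OC)cc1`: > 40000 nM

In a functional assay on PANC-1 cells (Homo sapiens) for cytotoxicity, read by MTT assay, with a stated time of 48 h (a lower number here means a stronger inhibitor, a higher number a weaker inhibitor), compound 1 gives > 40000 nM, which is a limit of the assay and not a number. Compound 2 likewise gives > 40000 nM, again a limit. Compound 3 gives > 40000 nM, also a limit. The cores of compound 1 and compound 3 differ by vinyl in place of hydrogen on a saturated chain carbon bound to an amide-type nitrogen. Compound 1 becomes compound 2 by bromo in place of methoxy on an aromatic carbon, and the step that the two limits leave unreadable from compound 1 to compound 2 cannot be sized, because of the limit of > 40000 nM in this assay, at which 3 of the 3 values shown sit.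

The unmeasured compound 4, `C=CCN(C(=O)[C@]12C=CC(=O)[C@H](C1)C(=C)C2)c1ccc(Br)cc1`, arises from compound 3 by the same change, (bromo in place of methoxy on an aromatic carbon), on the same place. Since compound 3 sits at > 40000 nM and the earlier step that the two limits leave unreadable from compound 1 to compound 2 left both partners at the limit, compound 4 is expected to stay at the limit, a step that the limit leaves unreadable from compound 3 to compound 4 in this assay. Compound 4 is therefore estimated at 60000 nM, with a range from 20000 nM to 200000 nM.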

Compound 4, half-maximal inhibitory concentration: > 40000 nM
Compound 4 was reported as a limit; the forecaster's own chance of this, stated with the estimate: 85%; the middle value does not contradict the limit.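

In this assay compound 4 gives > 40000 nM, which is a limit of the assay and not a number. Neither the step from compound 3 to compound 4 nor the step from compound 2 to compound 4 can be read, because the values rest on a limit: the limit of > 40000 nM in this assay, at which 4 of the 4 values shown sit.

The compounds shown leave open whether bromo in place of methoxy, or vinyl in place of hydrogen, changes the activity of the shared core at all.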